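The source may report more compounds than this note shows. Statements on the series, on what has been measured and on what is new or still open speak of the compounds shown alone.

Measured in a functional assay on the whole organism for agonist activity, with Mus musculus as the target; a higher number here means that more compound is needed for the effect, a lower number that less compound is needed:

Compound 1 `CC(=O)NCC#CCn1ccnc1`: > 100 mg/kg
Compound 2 `COC(=O)N(C)CC#CCn1ccnc1`: 4.5 mg/kg
Compound 3 `O=C1OCCN1CC#CCn1ccnc1`: 3 mg/kg

The entry for compound 1, > 100 mg/kg, is a limit of this assay and not a number. Among the compounds with values here, only two true numbers therefore remain. Compound 3 at 3 mg/kg and compound 2 at 4.5 mg/kg lie within the usual scatter of each other, so this pair cannot be ranked.

Compound 4 `Cc1cncn1CC#CCN1CCOC1=O` differs from compound 3 in one place: methyl in place of hydrogen on an aromatic carbon. This carbon lies next to the ring nitrogen and next to the ring atom that bears a large group.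

Within the data shown here, no measured pair here shows what such a methyl does, so the expectation is loose. The expected change is a 3.0-fold higher number from compound 3 to compound 4 (0.48 log units; beyond the scatter), a modest move towards a higher number, meaning that more compound would be needed. For compound 4 the estimated value is 9 mg/kg, with an expected range from 2 mg/kg to 50 mg/kg.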

Compound 4, dose for half-maximal effect: > 100 mg/kg
Compound 4 ended at the assay's limit; the forecaster's own chance of this, stated with the estimate: 15%; middle value at least 11-fold (1.04 log units) from the limit.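

In this assay, methyl in place of hydrogen on an aromatic carbon gives an at least 33-fold higher number from compound 3 to compound 4 (1.52 log units; beyond the scatter), a large step for the addition of a single carbon. Compound 4 gives > 100 mg/kg, which is a limit of the assay and not a number. The earlier compounds all carry hydrogen on this carbon, so only this pair shows that a change here can matter so strongly, and the true size of the step remains unknown because the value sits at a limit: the limit of > 100 mg/kg in this assay, at which 2 of the 4 values shown sit.

The compounds shown leave open whether a fluorine atom or an ethyl group on this same carbon would have a similar effect. They also leave open whether the same methyl would act alike on compound 2.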